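Swapping a thiophene sulfonamide for a chloro-methoxyphenyl one

The source may hold more compounds than are shown below. What is called first, only, known or untested is meant among the compounds shown, and "the series" means these compounds.

Measured so far:
- compound 1, `O=S(=O)(Nc1ccc(-c2nc3ccccc3o2)cc1)c1ccccc1C(F)(F)F`: > 100000 nM
- compound 2, `O=S(=O)(Nc1ccc2oc(-c3ccccc3)nc2c1)c1cccs1`: 97000 nM
- compound 3, `O=[N+]([O-])c1cc(S(=O)(=O)Nc2ccc3oc(-c4ccccc4)nc3c2)ccc1Cl`: 90000 nM

All three share a sulfonamide attached to a benzoxazole-type core and were tested in an ADME assay on HEK293 cells (Homo sapiens) for cytotoxicity, read by resazurin assay, with a stated time of 48 h; a higher number here means that more compound is tolerated, a lower number that less compound is tolerated. Compound 1 gives > 100000 nM, which is a limit of this assay rather than a number. Compound 2 gives 97000 nM and compound 3 gives 90000 nM; these two numbers lie within the usual scatter of each other, so neither can be said to be tolerated better than the other. Compound 2 therefore stands among values that are all very high, close to the limit of > 100000 nM in this assay, at which 1 of the 3 values shown sits.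

The next compound, compound 4 with `COc1ccc(Cl)cc1S(=O)(=O)Nc1ccc2oc(-c3ccccc3)nc2c1`, has not yet been measured in this assay. It differs from compound 2 only at the sulfonyl sulfur: 5-chloro-2-methoxyphenyl in place of thiophen-2-yl on a sulfonyl sulfur. Within the data shown here, no pair of measured compounds here isolates such a swap, so there is no measured step to lean on. Given that compound 2 gives 97000 nM and the other two compounds sit at similarly high values, the expected step from compound 2 to compound 4 is none beyond the scatter, and a 1.1-fold lower number from compound 2 to compound 4 (0.03 log units; within the scatter) is the estimated change. Compound 4 is thus expected to give about 90000 nM, in a range from 40000 nM to 150000 nM.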

Compound 4, half-maximal cytotoxic concentration: 74000 nM
For compound 4 the middle estimate is 1.2-fold (0.09 log units) above the measured one, within the range that was stated.
By their numbers in this assay, from the lowest: compounds 4, 3 and 2 (each within the scatter of the next). At a limit, above all of these: compound 1.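

In this assay, putting 5-chloro-2-methoxyphenyl in place of thiophen-2-yl on a sulfonyl sulfur gives a 1.3-fold lower number from compound 2 to compound 4 (0.12 log units; within the scatter). Among these compounds, this is the first pair here that differs in one place, and it shows that a five-membered aromatic ring with a sulfur atom and a larger six-membered carbon ring carrying chlorine and methoxy substituents cannot be told apart at this position, even though the earlier compounds offered no such direct test. Only compound 1 stands at a limit of the assay rather than at a number: the limit of > 100000 nM in this assay, at which 1 of the 4 values shown sits.

The compounds shown carry only aromatic rings on the sulfonyl sulfur, so it remains open whether an amine or a carboxylic acid on a ring at this place would shift the tolerated concentration beyond the scatter. From the compounds shown here alone, it is also open whether the same swap would stay this small on the core of compound 1, where the groups are arranged differently.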